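The source may report more compounds than this note shows. Statements on the series, on what has been measured and on what is new or still open speak of the compounds shown alone.

Series notes. For the measured compounds named here, compound 1 `C[C@H](Nc1cc(F)c(S(=O)(=O)Nc2cscn2)cc1Cl)c1cc(F)ccc1F` and compound 2 `CC1(C)CCN1Cc1cccc(F)c1CNc1cc(F)c(S(=O)(=O)Nc2cscn2)c(F)c1` are the two measured members. In an assay on HEK293 cells for inhibition of SCN8A/SCN1B (Homo sapiens), read by patch clamp, with a stated time of 20 min (a higher number here means a weaker inhibitor, a lower number a stronger inhibitor), compound 1 gives 119 nM, and in this assay compound 2 gives 60 nM. Going by the values given here, the two numbers lie within the usual scatter of each other, so no ranking between compound 1 and compound 2 is drawn from them, and no step between compounds differing in a single place has been measured in this set.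

Compound 3 `CN(Cc1cccc(F)c1CNc1cc(F)c(S(=O)(=O)Nc2cscn2)c(F)c1)C(C)(C)C` is not yet measured. Among the compounds with values here, it differs from compound 2 by methyl(tert-butyl)amino in place of 2,2-dimethylazetidin-1-yl on a saturated chain carbon bound to an aromatic carbon; the substituent that leaves and the one that enters carry the same count of heavy atoms, donors and acceptors, the ring being the only counted change. Within the data shown here, with no measured step available to anchor this change, the expected step from compound 2 to compound 3 is none beyond the scatter, written as a 1.3-fold higher number from compound 2 to compound 3 (0.12 log units; within the scatter). Compound 3 is estimated at 80 nM, in the range 30 nM to 250 nM.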

Compound 3, half-maximal inhibitory concentration in the SCN8A/SCN1B assay: 40 nM
Compound 3: the middle estimate sits 2.0-fold (0.30 log units) above what was measured; the range from low to high includes it.
By their numbers in the SCN8A/SCN1B assay, from the lowest: compounds 3, 2 and 1 (each within the scatter of the next, the first and the last beyond it).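

Methyl(tert-butyl)amino in place of 2,2-dimethylazetidin-1-yl on a saturated chain carbon bound to an aromatic carbon gives the first single-place step in the series, and in the SCN8A/SCN1B assay it reads a 1.5-fold lower number from compound 2 to compound 3 (0.18 log units; within the scatter). With this step inside the scatter, the four-membered ring is not required to keep the inhibition number in the same range for this pair, and the counted heavy atoms, donors and acceptors stay the same. In a physicochemical assay for lipophilicity, read by LC-MS, in phosphate buffer, measured as octanol-water partition, with a stated time of 1 h, at pH 7.4 (on this read-out higher numbers stand for higher lipophilicity and lower numbers for lower lipophilicity), compound 2 gives 1.8 and compound 3 gives 2.2. The change does separate the two compounds on lipophilicity, with no step beyond the scatter in inhibition to accompany it: the measured distribution coefficient of compound 2, 1.8, and of compound 3, 2.2, a number 0.40 log units higher (beyond the scatter).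

From the compounds shown here alone, it remains open how the inhibition number responds at this position to a smaller amine such as dimethylamino. The same question applies to an oxygen-bearing ring such as morpholin-4-yl.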